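Simplifying compound 3 to a 4-aminobutyl chain

This account rests on a few compounds, and the source may have more. Where it says the series, first, only, none or still open, it means among the compounds named here.

Of the compounds shown here, three built on one shared core have been tested in an ADME assay on microsomes from liver (Homo sapiens) for metabolic stability, read by LC-MS, tested at 1 uM; on this read-out lower numbers stand for slow clearance and higher numbers for fast clearance. Compound 1 `NCCOCCOc1ccc([C@H]2CC[C@]3(CC2)OOC2(O3)C3CC4CC(C3)CC2C4)cc1` carries a 2-(2-aminoethoxy)ethyl group on an oxygen on an aromatic ring. In this assay compound 1 returns < 7 mL.min-1.g-1, which is a limit of the assay and not a number. Compound 2 `c1cc([C@H]2CC[C@]3(CC2)OOC2(O3)C3CC4CC(C3)CC2C4)ccc1OCCCNC1CCOCC1` gives 10 mL.min-1.g-1. Compound 3 `CC(C)(O)CN1CCC(Oc2ccc([C@H]3CC[C@]4(CC3)OOC3(O4)C4CC5CC(C4)CC3C5)cc2)CC1` gives 18 mL.min-1.g-1, the highest of the two numbers shown, although a 1.8-fold higher number from compound 2 to compound 3 (0.26 log units; within the scatter) stays within the scatter. The step of an at least 2.5-fold higher number from compound 1 to compound 3 (0.41 log units; beyond the scatter) lies beyond the scatter, whereas an at least 1.4-fold higher number from compound 1 to compound 2 (0.15 log units; that floor lies within the scatter) rests on a floor that falls inside it.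

Compound 4 `NCCCCOc1ccc([C@H]2CC[C@]3(CC2)OOC2(O3)C3CC4CC(C3)CC2C4)cc1` is compound 3 with 4-aminobutyl in place of 1-(2-hydroxy-2-methylpropyl)piperidin-4-yl on an oxygen on an aromatic ring. The change takes the substituent back toward the open-chain amines of compounds 1 and 2. Compound 4 is expected to move toward the limit because compound 1 with its own open-chain amine sits at the limit of < 7 mL.min-1.g-1 in this assay, at which 1 of the 3 values shown sits. Compound 4 is thus expected to give a lower number, a 2.3-fold lower number from compound 3 to compound 4 (0.35 log units; beyond the scatter). Compound 4 is estimated at 8 mL.min-1.g-1, ranging from 4 mL.min-1.g-1 to 16 mL.min-1.g-1.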

Compound 4, intrinsic clearance in microsomes: < 7 mL.min-1.g-1
Compound 4 was reported as a limit; the forecaster's own chance of this, stated with the estimate: 40%; at least 1.1-fold (0.05 log units) between middle value and limit.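

In this assay, 4-aminobutyl in place of 1-(2-hydroxy-2-methylpropyl)piperidin-4-yl on the oxygen on the aromatic ring gives an at least 2.5-fold lower number from compound 3 to compound 4 (0.41 log units; beyond the scatter), so a plain open chain at this position can shift the read-out by more than the scatter. Set against the open chain that carries oxan-4-yl on its amine, the change gives an at least 1.4-fold lower number from compound 2 to compound 4 (0.15 log units; that floor lies within the scatter), so that comparison shows no firm order. Compound 1 and compound 4, both open chains ending in an unsubstituted amine, now each sit at a limit of the assay and not at a number, and the step between them cannot be read: the limit of < 7 mL.min-1.g-1 in this assay, at which 2 of the 4 values shown sit.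

Going by these compounds, how the oxygen in the chain of compound 1 compares with the all-carbon chain of compound 4 therefore stays open. Also open, on these data alone, is whether the piperidine ring or its 2-hydroxy-2-methylpropyl group goes with the higher number of compound 3, which a piperidin-4-yl group with a plain methyl on its nitrogen could help to separate.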